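The compounds below may be only part of what the source reports. "The series", "measured", "known", "first", "only" and "open" are said of these compounds alone.

Measured so far:
compound 1, `CCN1CCN(C[C@H]2CN(c3ccc(-n4cc(-c5ccccn5)cn4)c(F)c3)C(=O)O2)CC1`, 706000 nM
compound 2, `O=C1O[C@@H](CN2CCC(c3ccc(F)cc3)CC2)CN1c1ccc(-n2cc(-c3ccccn3)cn2)c(F)c1`, <= 19400 nM
compound 3, `O=C1O[C@@H](CSc2cccs2)CN1c1ccc(-n2cc(-c3ccccn3)cn2)c(F)c1`, 8500 nM

In a physicochemical assay for solubility, read by HPLC, with a stated time of 24 h (on this read-out lower numbers stand for lower solubility and higher numbers for higher solubility), compound 3 gives the lowest of the two numbers; the nearest number is that of compound 1, and the gap is an 83-fold lower number from compound 1 to compound 3 (1.92 log units; beyond the scatter). The value of compound 2 is a limit of this assay, not a number, as the limit of <= 19400 nM in this assay, at which 1 of the 3 values shown sits, records.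

Compound 4, `O=C1O[C@@H](CNC(=O)C(F)(F)F)CN1c1ccc(-n2cc(-c3ccccn3)cn2)c(F)c1`, has not yet been measured. It differs from compound 3 in one place: ((trifluoromethyl)carbonyl)amino in place of (thiophen-2-yl)sulfanyl on a saturated chain carbon bound to a saturated ring carbon. Going by the values given here, the only measured step on this part of the shared core is the one from compound 1 to compound 3, where an 83-fold lower number from compound 1 to compound 3 (1.92 log units; beyond the scatter) accompanied the arrival of the (thiophen-2-yl)sulfanyl group. Compound 4 now removes that same group again and puts ((trifluoromethyl)carbonyl)amino in its place, a change for which no direct precedent exists among these compounds. The step is therefore expected to be a 3.5-fold higher number from compound 3 to compound 4 (0.55 log units; beyond the scatter), a rise far smaller than the earlier fall. Compound 4 is expected to give about 30000 nM in this assay, with a likely range from 6000 nM to 150000 nM.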

Compound 4, solubility: 114000 nM
The estimate for compound 4 lay 3.8-fold (0.58 log units) below the measured number, within the range that was stated.
By their numbers in this assay, from the lowest: compound 3; then compound 4; then compound 1.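

In this assay, the group on a saturated chain carbon bound to a saturated ring carbon now has a second measured swap, and it shows that the low number of the thiophene compound is not set by the shared core alone: a 13-fold higher number from compound 3 to compound 4 (1.13 log units; beyond the scatter). The ((trifluoromethyl)carbonyl)amino group thus regains much of what was lost with (thiophen-2-yl)sulfanyl, but it does not reach the number given with 4-ethylpiperazin-1-yl: a 6.2-fold lower number from compound 1 to compound 4 (0.79 log units; beyond the scatter). Both (thiophen-2-yl)sulfanyl and ((trifluoromethyl)carbonyl)amino carry no net charge, yet their numbers lie far apart, so having no net charge does not by itself fix the number at this position.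

This swap removes a ring and adds a hydrogen-bond donor and a double bond outside aromatic rings in a single move, and nothing given here separates these differences or explains the step. Where an acetylamino group, a free amine or a carboxylic acid on this same chain carbon would fall among these numbers remains open.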